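The compounds below may be only part of what the source reports. "The series", "measured", "known", "first", "only" and "open" are said of these compounds alone.

Measured so far in an ADME assay on cells (Hepatocyte, Mus musculus) for metabolic stability, with a stated time of 30 min; a lower number here means that less of the compound is left, a higher number that more of the compound is left:
compound 1 `NC1CCC(CN2CCN(c3cc(=O)c4cc(C(F)(F)F)cc([N+](=O)[O-])c4s3)CC2)CC1`: 107%
compound 2 `O=C(NC1CCC(CN2CCN(c3cc(=O)c4cc(C(F)(F)F)cc([N+](=O)[O-])c4s3)CC2)CC1)c1ccccc1`: 90.6%

Going by the values given here, compound 2 holds the lower of the two numbers in this assay; its only neighbour is compound 1, and the step of a number 16.4 percentage points lower from compound 1 to compound 2 (beyond the scatter) separates them, beyond the scatter but modest in size.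

Compound 3 `O=c1cc(N2CCN(CC3CCC(O)CC3)CC2)sc2c([N+](=O)[O-])cc(C(F)(F)F)cc12` is reached from compound 2 by one change: hydroxy in place of benzamido on a saturated ring carbon

Among the compounds with values here, the single measured step that bears on this change is the one from compound 1 to compound 2, a number 16.4 percentage points lower from compound 1 to compound 2 (beyond the scatter), where benzoyl came in for hydrogen on the amine nitrogen. The step to compound 3 takes the benzamido group away again and leaves a hydroxy in its place, so the expected direction is a modest rise, of about the size seen between compound 1 and compound 2, or a change that stays within the scatter.

For compound 3 the expected step from compound 2 is a number 9.4 percentage points higher from compound 2 to compound 3 (within the scatter). Compound 3 is therefore estimated at 100%, in the range 85% to 112%.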

Compound 3, percent of the compound remaining: 51.2%
Estimate against measurement, compound 3: 48.8 percentage points above; the whole stated range lies above it.
By their numbers in this assay, from the lowest: compound 3; then compound 2; then compound 1.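

In this assay, going by these compounds alone, the group on the saturated ring carbon matters far more than the first pair of compounds suggested: hydroxy in place of benzamido gives a number 39.4 percentage points lower from compound 2 to compound 3 (beyond the scatter) and hydroxy in place of amino gives a number 55.8 percentage points lower from compound 1 to compound 3 (beyond the scatter) on the same carbon. Taking away the benzamido group therefore does not by itself bring the number back towards that of compound 1, and the two groups carrying nitrogen both stand well apart from the hydroxy. Nothing shown here accounts for this drop.

The compounds shown leave open whether the low number belongs to the hydroxy alone or extends to other oxygen groups on this carbon, such as a methoxy group or a carboxylic acid. They also leave open whether a methylamino group or a smaller amide such as acetamido would stay close to compound 1 and compound 2.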